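From Methoxy to Hydroxy on Compound 1

This account rests on a few compounds, and the source may have more. Where it says the series, first, only, none or still open, it means among the compounds named here.

Within the data shown here, in a functional assay on HUVEC cells (Homo sapiens) for inhibition (on this read-out lower numbers stand for stronger inhibition and higher numbers for weaker inhibition), compound 1 (`COc1ccc2c(c1)c(OC(C)C)c(C(N)=O)[s+]2[O-]`) gives 9600 nM as the only exact number available. Compound 2 (`CC(C)OC1=C(C(N)=O)S(=O)(=O)c2ccc(O)cc21`) stands at < 4000 nM as a limit and not a number. Compound 3 (`CC(C)Oc1c(C(N)=O)[s+]([O-])c2ccc(O)cc12`) departs from compound 1 by a single change (hydrogen in place of methyl on an oxygen on an aromatic ring): hydrogen in place of methyl on an oxygen on an aromatic ring, methoxy to hydroxy. Among the measured compounds shown here, no measured step covers this change. A small move towards stronger inhibition is expected (a 2.1-fold lower number from compound 1 to compound 3 (0.33 log units; beyond the scatter)). In this assay compound 3 is estimated at 4500 nM with an expected range between 1500 nM and 11000 nM as the likely span.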

Compound 3, half-maximal inhibitory concentration: 5000 nM
The estimate for compound 3 lay 1.1-fold (0.05 log units) below the measured number; low and high end bracket the measured number.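

In this assay, the change from methoxy to hydroxy gives a 1.9-fold lower number from compound 1 to compound 3 (0.28 log units; within the scatter), so the two compounds cannot be told apart on this read-out. This pair is the only one shown with two exact numbers, and it gives this position its first measured step: with hydrogen in place of methyl on this oxygen, the number stays within the scatter. Compound 2 offers only a limit and not a number: the limit of < 4000 nM in this assay, at which 1 of the 3 values shown sits.

On these data alone, what remains open is whether a longer chain on this oxygen, such as ethyl or propyl, would shift the number. The same question stands for a chain ending in an amine or a carboxylic acid.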